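Chloro in place of trifluoromethyl: notes toward compound 4

A few compounds are considered here, and "the series" means these few. Any claim that something is new, unique, unknown or untested is made for them only; others in the source may bear on it.

Compound 1 `Cc1cc(CCC(=O)O)ccc1-c1noc(-c2ccc(OC(C)C)c(C(F)(F)F)c2)n1` reaches only a limit in a functional assay on CHO cells with sphingosine 1-phosphate receptor 2 (Homo sapiens) as the target, read by GTPgammaS binding; on this read-out lower numbers stand for an effect already at smaller amounts and higher numbers for an effect only at larger amounts of compound; the value recorded for compound 1 is > 10000 nM. Compound 2 `CCOc1ccc(-c2nc(-c3ccc(CCC(=O)O)cc3C)no2)cc1C(F)(F)F` likewise gives only a limit, > 10000 nM. Compound 3 `COc1ccc(-c2nc(-c3ccc(CCC(=O)O)cc3C)no2)cc1C(F)(F)F` also stands at a limit, > 10000 nM. The steps a step that the two limits leave unreadable from compound 1 to compound 2, a step that the two limits leave unreadable from compound 1 to compound 3 and a step that the two limits leave unreadable from compound 2 to compound 3 therefore cannot be sized; all three values sit at the limit of > 10000 nM in this assay, at which 3 of the 3 values shown sit. Compound 4 `Cc1cc(CCC(=O)O)ccc1-c1noc(-c2ccc(OC(C)C)c(Cl)c2)n1` differs from compound 1 by chloro in place of trifluoromethyl on an aromatic carbon. For the measured compounds named here, none of the measured steps touches this carbon, and all measured members are limits, so no readable step bears on the change. Compound 4 is expected to remain at the limit, estimated at 10000 nM with a range of 3000 nM to 30000 nM. The expected step of a number no higher from compound 1 to compound 4 (the limit leaves the size open) is thus none beyond the scatter.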

Compound 4, half-maximal effective concentration: > 10000 nM
Compound 4 gave a limit, no number (the forecaster's own chance of this, stated with the estimate: 85%); the middle value sits exactly at the limit.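

In this assay compound 1 and compound 4 both give limits, not numbers, so no step between them can be read: the limit of > 10000 nM in this assay, at which 4 of the 4 values shown sit.

The compounds shown leave open whether swapping trifluoromethyl for chloro changes the read-out at all, and whether any member of this series gives a number in this assay.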